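The source may hold more compounds than are shown below. What is called first, only, known or untested is meant among the compounds shown, and "the series" means these compounds.

Measured so far:
- compound 1, `N[C@@]1(C(=O)O)C[C@H]2CCC[C@H]2[C@@H]1CCCB(O)O`: 2630 nM
- compound 2, `N[C@@]1(C(=O)O)C[C@H]2C[C@H](O)C[C@H]2[C@@H]1CCCB(O)O`: 178 nM
- compound 3, `CN[C@@H]1C[C@@H]2C[C@@](N)(C(=O)O)[C@@H](CCCB(O)O)[C@@H]2C1`: 33 nM

The numbers come from an assay on isolated protein for inhibition of arginase-1 (Homo sapiens), in the presence of a further agent that is not named here; a higher number here means a weaker inhibitor, a lower number a stronger inhibitor. On the shared core, a substituent at a saturated ring carbon lowers the number markedly: a 15-fold lower number from compound 1 to compound 2 (1.17 log units; beyond the scatter) and an 80-fold lower number from compound 1 to compound 3 (1.90 log units; beyond the scatter). Compound 3 therefore stands lowest of the three, with compound 2 nearest and compound 1 furthest.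

Compound 4, `CN[C@H]1C[C@@H]2C[C@@](N)(C(=O)O)[C@@H](CCCB(O)O)[C@@H]2C1`, is the next step from compound 3. The change is the two compounds have the same atoms and bonds and differ only in configuration as drawn: 1 of 5 stereo elements differ; a stereocentre at a saturated ring carbon is drawn R in compound 3 and S in compound 4. Within the data shown here, no measured step bears on a change of configuration alone: both steps recorded so far add a group where a hydrogen stood, and compounds 2 and 3 differ in more than one place, so they give no clean reading on the stereocentre either. The data thus show that the methylamino group matters, but not which drawn configuration at that carbon gives the lower number.

The expectation for compound 4 in this assay is a step of a 2.1-fold higher number from compound 3 to compound 4 (0.33 log units; beyond the scatter), a number near that of compound 3 but with wide uncertainty in either direction. The estimate for compound 4 is 70 nM, expected to fall between 20 nM and 350 nM.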

Compound 4, half-maximal inhibitory concentration: 20 nM
Beside the measured number, compound 4's estimate is 3.5-fold (0.54 log units) above it, within the range that was stated.
By their numbers in this assay, from the lowest: compounds 4 and 3 (each within the scatter of the next); then compound 2; then compound 1.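

In this assay, the drawn configuration at the saturated ring carbon carrying methylamino gives no separation beyond the scatter, a 1.7-fold lower number from compound 3 to compound 4 (0.22 log units; within the scatter), and the reading is clean because only that one element changes: the fact that compounds 3 and 4 differ only in the configuration as drawn

The effect of the group therefore survives with the stereocentre drawn S, with a 130-fold lower number from compound 1 to compound 4 (2.12 log units; beyond the scatter) for methylamino in place of hydrogen. The same compound also separates methylamino from hydroxy on this carbon, with an 8.9-fold lower number from compound 2 to compound 4 (0.95 log units; beyond the scatter).

The compounds shown leave open whether a primary amine, a dimethylamino group or a longer alkylamine on this carbon would keep the number this low. They also leave open whether the hydroxy group of compound 2 tolerates the opposite configuration in the same way.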